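The source may report more compounds than this note shows. Statements on the series, on what has been measured and on what is new or still open speak of the compounds shown alone.

Measured compounds in a functional assay on L1210 cells (Mus musculus), with a stated time of 1 days; a higher number here means a more potent compound, by a factor of ten per unit of this negative logarithm, a lower number a less potent compound:
compound 1, `CC1=C(N2CC2)C(=O)C(Cc2ccccc2)=C(N2CC2)C1=O`: 4.26
compound 2, `CC1=C(N2CC2)C(=O)C(CCCOC(N)=O)=C(N2CC2)C1=O`: 5.48

Compound 2 holds the higher of the two values; compound 1 is the nearest, and the step of a number 1.22 log units higher from compound 1 to compound 2 (beyond the scatter) separates them. Compound 3, `CC1=C(N2CC2)C(=O)C(C(C)C)=C(N2CC2)C1=O`, is not yet measured. Against compound 2 the change is a group of 3 heavy atoms (3 carbon; no ring) in place of a group of 7 heavy atoms (4 carbon, 1 nitrogen, 2 oxygen; no ring), on a double-bonded ring carbon. Among the measured compounds shown here, the only measured step at the same ring carbon is the one from compound 1 to compound 2, where 2-(carbamoyloxy)ethyl in place of phenyl brought a number 1.22 log units higher from compound 1 to compound 2 (beyond the scatter). Compound 3 moves the other way: the group of 7 heavy atoms (4 carbon, 1 nitrogen, 2 oxygen) that compound 2 carries gives way to isopropyl, so that, as in compound 1, only a hydrocarbon group remains at that carbon. The expectation is therefore a drop in this assay, of roughly a number 0.88 log units lower from compound 2 to compound 3 (beyond the scatter), though isopropyl is not phenyl and a single step is a loose gauge of the size. Compound 3 is estimated at 4.6, with a range from 4 to 5.2.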

Compound 3, logarithm of the reciprocal of the active concentration, log(1/C): 4.69
Compound 3: the middle estimate sits 0.09 log units below what was measured; the range from low to high includes it.
By their numbers in this assay, from the lowest: compound 1; then compound 3; then compound 2.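

In this assay, the double-bonded ring carbon next to an aziridin-1-yl group now has three groups compared, and the two hydrocarbon groups do not read alike: with isopropyl in place of benzyl, the result is a number 0.43 log units higher from compound 1 to compound 3 (beyond the scatter). The group of 7 heavy atoms in compound 2 still gives the highest number of the three, since replacing it with isopropyl gives a number 0.79 log units lower from compound 2 to compound 3 (beyond the scatter), and isopropyl therefore falls between benzyl and that group in the order of values. The gain from the chain seen earlier thus includes a difference between the two hydrocarbon groups, and no measurement here on the compounds accounts for this order.

On these data alone, whether the value of compound 2 goes with the carbamoyloxy end or with the chain that carries it stays open, and a plain propyl group or a chain ending in a hydroxyl group would separate the two. Also open, as far as these compounds go, is how methyl at this carbon, or an amine or a carboxylic acid at the end of the chain, would read in this assay.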